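Indolyl in Place of Pyrimidinyl: an Expected Recovery

The compounds below may be only part of what the source reports. "The series", "measured", "known", "first", "only" and "open" are said of these compounds alone.

Compound 1, `Cc1ccnnc1N1CCN(c2ncccn2)CC1`, in a functional assay on BV-2 cells (Mus musculus) for inhibition, read by ELISA, with a stated time of 16 h; on this read-out lower numbers stand for stronger inhibition and higher numbers for weaker inhibition: > 100000 nM, a limit of the assay.
Compound 2, `COc1ccc(-c2cc(C)c(N3CCN(c4ncccn4)CC3)nn2)cc1`, in this assay: 5200 nM.
Compound 3, `Cc1cc(-c2cncnc2)nnc1N1CCN(c2ncccn2)CC1`, in this assay: > 100000 nM, a limit of the assay.

Compound 3 stands at the limit of the assay, and it is not alone there: the limit of > 100000 nM in this assay, at which 2 of the 3 values shown sit. Only compound 2, which carries 4-methoxyphenyl on the shared core, gives a readable number. Among the compounds with values here, the steps that bear on the change are an at least 19-fold lower number from compound 1 to compound 2 (1.28 log units; beyond the scatter) and an at least 19-fold higher number from compound 2 to compound 3 (1.28 log units; beyond the scatter), both large, while a step that the two limits leave unreadable from compound 1 to compound 3.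

Compound 4, `Cc1cc(-c2ccc3[nH]ccc3c2)nnc1N1CCN(c2ncccn2)CC1`, differs from compound 3 in one place: 1H-indol-5-yl in place of pyrimidin-5-yl on an aromatic carbon. The group that enters brings one six-membered aromatic ring of carbon only, as does the 4-methoxyphenyl of compound 2, whereas the pyrimidin-5-yl that leaves carries two nitrogen atoms, as does the group of compound 3 that sits at the limit. The expectation for compound 4 is therefore a return toward the numbers of compound 2, a step in the direction of stronger inhibition, estimated as an at least 25-fold lower number from compound 3 to compound 4 (1.39 log units; beyond the scatter). Because compound 3 gives only > 100000 nM, the size of that step cannot be read with confidence. Compound 4 is estimated at 4000 nM, within 800 nM to 40000 nM.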

Compound 4, half-maximal inhibitory concentration: 85100 nM
The estimate for compound 4 lay 21-fold (1.33 log units) below the measured number, outside the stated range (above it).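

In this assay, the step of a 16-fold higher number from compound 2 to compound 4 (1.21 log units; beyond the scatter) shows that at this position, on an aromatic carbon of the shared core, 1H-indol-5-yl does not match 4-methoxyphenyl. Compound 2 and compound 4 both carry a six-membered aromatic ring of carbon only at this place, so that ring alone does not set the number among the compounds shown. The steps of an at least 1.1-fold lower number from compound 3 to compound 4 (0.07 log units; that floor lies within the scatter) and an at least 1.1-fold lower number from compound 1 to compound 4 (0.07 log units; that floor lies within the scatter) give only floors, and they cannot show how far compound 4 truly stands from the two compounds without a readable number, because of where those two values sit: the limit of > 100000 nM in this assay, at which 2 of the 4 values shown sit.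

The compounds shown leave open whether the gap between compound 2 and compound 4 follows the methoxy group or the fused five-membered ring, which a plain phenyl, a 4-hydroxyphenyl or a 4-aminophenyl at the same place would help to separate. They also leave open how much the methyl group contributes, since all four compounds keep it, and whether a hydrogen, a chlorine or an ethyl group in its place would alter the picture.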